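From a diethylamino to a dimethylamino side chain

The compounds below may be only part of what the source reports. "The series", "measured", "known", "first", "only" and "open" are said of these compounds alone.

Among the measured compounds shown here, in a functional assay on A549 cells (Homo sapiens) for antiproliferative activity, read by MTT assay, with a stated time of 48 h (a higher number here means a weaker inhibitor, a lower number a stronger inhibitor), compound 3 (`CCN(CC)CCCn1c(N)c(-c2nc3ccccc3n2C)c2nc(C#N)c(C#N)nc21`) gives 10700 nM, the lowest of the exact numbers so far. Compound 1 (`CN(C)CCCCn1c(N)c(-c2nc3ccccc3s2)c2nc(C#N)c(C#N)nc21`) gives 35800 nM, a higher number by a margin beyond the scatter. Compound 2 (`CN(C)CCn1c(N)c(-c2nc3ccccc3n2C)c2nc(C#N)c(C#N)nc21`) reaches only a limit, > 50000 nM.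

Compound 4 (`CN(C)CCCCn1c(N)c(-c2nc3ccccc3n2C)c2nc(C#N)c(C#N)nc21`) keeps the core of compound 3 and alters only the side chain: (dimethylamino)methyl in place of diethylamino on a saturated chain carbon, three bonds along the chain from an aromatic nitrogen. Here (dimethylamino)methyl stands in place of diethylamino on a saturated chain carbon, three bonds along the chain from an aromatic nitrogen, so that 3-(diethylamino)propyl becomes 4-(dimethylamino)butyl.

The closest measured evidence is an at least 4.6-fold lower number from compound 2 to compound 3 (0.66 log units; beyond the scatter), a step on the same core in which (diethylamino)methyl replaced dimethylamino. The change to compound 4 also returns to a dimethylamino end, but it keeps the chain long rather than shortening it. Compound 1 carries the same 4-(dimethylamino)butyl chain on a different core and gives 35800 nM. A shift in this assay towards a higher number is therefore expected, smaller than the measured step. The expected change is a 1.7-fold higher number from compound 3 to compound 4 (0.23 log units; within the scatter), an estimate of modest size. For compound 4 the estimated value is 18000 nM, with an expected range of 7000 nM to 45000 nM.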

Compound 4, half-maximal inhibitory concentration: 6150 nM
Estimate against measurement, compound 4: 2.9-fold (0.47 log units) above; the whole stated range lies above it.
By their numbers in this assay, from the lowest: compounds 4 and 3 (each within the scatter of the next); then compound 1. At a limit, above all of these: compound 2.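

On the shared core, 4-(dimethylamino)butyl in place of 3-(diethylamino)propyl moves the number in this assay only within the scatter, a 1.7-fold lower number from compound 3 to compound 4 (0.24 log units; within the scatter), so a dimethylamino end does not by itself go with the weak result of compound 2. From the compounds shown here alone, with the dimethylamino end kept, the 4-(dimethylamino)butyl chain in place of the chain of compound 2 gives an at least 8.1-fold lower number from compound 2 to compound 4 (0.91 log units; beyond the scatter), a step whose full size stays unknown, as compound 2 stands at a limit: the limit of > 50000 nM in this assay, at which 1 of the 4 values shown sits. With the 4-(dimethylamino)butyl chain held constant, 1-methyl-1H-benzimidazol-2-yl in place of 1,3-benzothiazol-2-yl on an aromatic carbon gives a 5.8-fold lower number from compound 1 to compound 4 (0.77 log units; beyond the scatter), which shows that the group at this aromatic carbon also changes the result by a margin beyond the scatter.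

The compounds shown leave open how chain length and the amine end act separately, a question that 3-(dimethylamino)propyl and 4-(diethylamino)butyl chains on the shared core could settle. Also open, going by these compounds, is how a chain longer than 4-(dimethylamino)butyl, or one ending in a ring amine such as piperidine or morpholine, would read in this assay.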